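The source may report more compounds than this note shows. Statements on the series, on what has been measured and on what is new or still open speak of the compounds shown alone.

Measured compounds in a functional assay on L1210 cells (Mus musculus) for inhibition; a lower number here means a stronger inhibitor, a higher number a weaker inhibitor:

Compound 1 `O=C1/C(=C/c2ccc(Br)cc2)Cc2ccccc21` gives 64800 nM
Compound 2 `Cc1ccc(/C=C2\Cc3ccccc3C2=O)cc1` gives 59100 nM
Compound 3 `O=C1/C(=C/c2ccc(Br)cc2)CCc2ccccc21` gives 202000 nM

Compound 1 and compound 2 share one core and differ in a single place: methyl in place of bromo on an aromatic carbon. In this assay the step is a 1.1-fold lower number from compound 1 to compound 2 (0.04 log units; within the scatter), so the two compounds cannot be told apart by their numbers.

Compound 3 carries the bromo substituent on a second core. The difference between the core of compound 1 and the core of compound 3 is not broken down here. Compound 3 has the highest number of the three measured compounds, beyond the scatter against both compound 1 and compound 2, so the core of compound 3 is the weaker of the two cores within this small set.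

Compound 4 `Cc1ccc(/C=C2\CCc3ccccc3C2=O)cc1` is not yet measured. It differs from compound 3 in one place: methyl in place of bromo on an aromatic carbon. This is the same change as from compound 1 to compound 2, made on the other core. Going by the values given here, only one such step is known, and it lies within the scatter. On that basis the step from compound 3 to compound 4 is expected to be a 1.1-fold lower number from compound 3 to compound 4 (0.03 log units; within the scatter), close to the earlier one, because the step from compound 1 to compound 2 is a 1.1-fold lower number from compound 1 to compound 2 (0.04 log units; within the scatter). For compound 4 in this assay the estimated value is 190000 nM, with a likely range from 100000 nM to 380000 nM. Since compound 3 already gives a high number, there is some chance the assay reports only a limit for compound 4.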

Compound 4, half-maximal inhibitory concentration: 161000 nM
Beside the measured number, compound 4's estimate is 1.2-fold (0.07 log units) above it; low and high end bracket the measured number.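

In this assay, methyl in place of bromo on the second core gives a 1.3-fold lower number from compound 3 to compound 4 (0.10 log units; within the scatter), so the two compounds cannot be told apart by their numbers. Set beside the same change on the first core, the new step shows no difference that can be read: the same change on two cores in this assay, a 1.1-fold lower number (0.04 log units; within the scatter) from compound 1 to compound 2 and a 1.3-fold lower number (0.10 log units; within the scatter) from compound 3 to compound 4, 1.1-fold (0.06 log units) apart, within the scatter of two such steps

Within this series, the exchange of bromo for methyl therefore leaves the number within the scatter on both cores, and the flat result carries from one core to the other. Going by these compounds alone, this rests on only two pairs and one exchange at one place, and it does not show that a step large enough to lie beyond the scatter would carry across the cores in the same way, as neither step here is of that kind.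

Open, as far as these compounds go, is whether an amine, a carboxylic acid or a longer chain in place of the bromo or methyl group, on an aromatic carbon para to a large group, would move the number beyond the scatter on either core. If one did, it remains open whether the step would match on the core of compound 1 and the core of compound 3.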